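Series notes: chloro in place of methoxy, second occurrence

The compounds below may be only part of what the source reports. "The series", "measured", "known", "first", "only" and "open" are said of these compounds alone.

Compound 1 `COc1ccc2[nH]c(C)c(Br)c(=O)c2c1` gives 1.62 in a physicochemical assay for lipophilicity, at pH 7.4; a lower number here means a more polar compound, a higher number a more lipophilic compound. Compound 2 `Cc1[nH]c2ccc(Cl)cc2c(=O)c1Br` gives 2.02 in this assay; the change chloro in place of methoxy on an aromatic carbon made a step of a number 0.40 log units higher from compound 1 to compound 2 (beyond the scatter). Compound 3 `COc1ccc2[nH]c(C)c(Cc3ccccc3)c(=O)c2c1` gives 2.53 in this assay; its core differs from the core of compound 1 by benzyl in place of bromo on an aromatic carbon, a step of a number 0.91 log units higher from compound 1 to compound 3 (beyond the scatter). Compound 4 `Cc1[nH]c2ccc(Cl)cc2c(=O)c1Cc1ccccc1` is not yet measured. It differs from compound 3 by chloro in place of methoxy on an aromatic carbon, the same change as between compound 1 and compound 2, with the place described in the same words; among the compounds shown this change occurs twice. For compound 4 in this assay a step of a number 0.40 log units higher from compound 3 to compound 4 (beyond the scatter) is expected, resting on the earlier step of a number 0.40 log units higher from compound 1 to compound 2 (beyond the scatter) for the same change. Compound 4 is therefore estimated at 2.93, between 2.55 and 3.3.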

Compound 4, distribution coefficient: 2.79
The estimate for compound 4 lay 0.14 log units above the measured number; the measured number falls inside the stated range.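

In this assay, chloro in place of methoxy gives a number 0.40 log units higher from compound 1 to compound 2 (beyond the scatter) on the core bearing bromo, while the same change on the core bearing benzyl gives a number 0.26 log units higher from compound 3 to compound 4 (within the scatter). The second step cannot be told apart from repeat measurements, so the step beyond the scatter seen on the first core is not confirmed on the second, and two occurrences do not show whether the size of the change depends on the core. No supporting measurement bears on why the two steps read as they do.

Open, on these data alone, is how this place behaves with an amine or a carboxylic acid in place of chloro or methoxy. Also open, as far as these compounds go, is whether a longer chain in place of benzyl would alter the step.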